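Cytotoxicity in Macrophages: Three Compounds and an Expected Fourth

The source may report more compounds than this note shows. Statements on the series, on what has been measured and on what is new or still open speak of the compounds shown alone.

The measured compounds, with their readings in an ADME assay on cells (Macrophage, Mus musculus) for cytotoxicity, read by resazurin assay, with a stated time of 3 days (on this read-out higher numbers stand for weaker inhibition and lower numbers for stronger inhibition), are:
compound 1, `O=C(Nc1cc(C(F)(F)F)cc(C(F)(F)F)c1)c1cc(F)ccc1O`, for which compound 1 gives 2500 nM;
compound 2, `O=C(Nc1cccc(C(F)(F)F)c1)c1cc(Cl)ccc1O`, for which compound 2 gives 5900 nM;
compound 3, `O=C(Nc1cccc(Br)c1)c1cc(Cl)ccc1O`, for which compound 3 gives 5700 nM.

Compound 1 has the lowest reading of the three in this assay, and its gap to each of the other two lies beyond the usual scatter. Compound 2 and compound 3 differ in one place, (bromo in place of trifluoromethyl on an aromatic carbon), and in this assay this gave a 1.0-fold lower number from compound 2 to compound 3 (0.01 log units; within the scatter).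

Compound 4, `O=C(Nc1cc(Br)cc(C(F)(F)F)c1)c1cc(F)ccc1O`, has not yet been measured. It differs from compound 1 in one place, (bromo in place of trifluoromethyl on an aromatic carbon). This is the same kind of change as that from compound 2 to compound 3 rather than the same change: in compound 1 the aromatic carbon that carries the leaving group is also meta to a trifluoromethyl group, which the corresponding place in compound 2 lacks. How the core of compound 1 differs from that of compound 2 is not broken down here.

The expectation for compound 4 rests on compound 1 with 2500 nM and on the earlier step of the same kind, a 1.0-fold lower number from compound 2 to compound 3 (0.01 log units; within the scatter), which stayed within the scatter. The expected step is no change at the digits printed from compound 1 to compound 4 (within the scatter). Compound 4 is therefore estimated at 2500 nM in this assay, with a range from 1200 nM to 5200 nM.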

Compound 4, half-maximal inhibitory concentration: 4700 nM
The estimate for compound 4 lay 1.9-fold (0.27 log units) below the measured number, and the stated range covers the measured number.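

In this assay, bromo in place of trifluoromethyl on the core of compound 1 gave a 1.9-fold higher number from compound 1 to compound 4 (0.27 log units; within the scatter), so the change again left the reading within the usual scatter, as it had on the other core. Set side by side, the two steps cannot be told apart: the same change on two cores in this assay, a 1.0-fold lower number (0.01 log units; within the scatter) from compound 2 to compound 3 and a 1.9-fold higher number (0.27 log units; within the scatter) from compound 1 to compound 4, 1.9-fold (0.29 log units) apart, within the scatter of two such steps. This shows that, for these two pairs and in this one assay, the change carried from one core to the other without a difference that the measurements can resolve; it does not show that the two steps are truly equal, that the same would hold on any further core, or why the reading stayed within the scatter.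

The compounds shown compare only trifluoromethyl and bromo at the changed place, so how a nitrile, a methoxy group, an amine or a carboxylic acid would read there remains open. As far as these compounds go, compound 1 and compound 2 differ in more than one place, so what each difference between their cores contributes on its own also remains open, as does whether the change would carry over in the same way in any other assay.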